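The source may report more compounds than this note shows. Statements on the series, on what has been measured and on what is new or still open speak of the compounds shown alone.

Three related compounds have been measured in a functional assay on K562 cells (Homo sapiens), read by MTT assay, with a stated time of 72 h; on this read-out lower numbers stand for stronger inhibition and higher numbers for weaker inhibition. Compound 1 `C#Cc1cn([C@@H]2O[C@H](CO)[C@@H](O)[C@H]2O)c2ncnc(NC)c12` gives > 20000 nM, which is a limit and not a number. Compound 2 `Cc1nc(N)c2c(-c3ccoc3)cn([C@@H]3O[C@H](CO)[C@@H](O)[C@H]3O)c2n1` gives > 20000 nM, also a limit. Compound 3 `Nc1nc2c(c(-c3ccccc3)cn2[C@@H]2O[C@H](CO)[C@@H](O)[C@H]2O)c(=O)[nH]1` gives > 20000 nM, again a limit. Compound 2 therefore has no exact position on the scale, and all the data so far sit at one point: the limit of > 20000 nM in this assay, at which 3 of the 3 values shown sit.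

The next compound, compound 4 `Cc1nc(N)c2c(I)cn([C@@H]3O[C@H](CO)[C@@H](O)[C@H]3O)c2n1`, carries iodo in place of furan-3-yl on an aromatic carbon of a five-membered aromatic ring with 1 nitrogen, part of a fused or bridged system of two rings: iodo in place of furan-3-yl on an aromatic carbon. For the measured compounds named here, no measured pair shows what a change at this place does in this assay, so the expectation is weakly founded. Little or no change beyond the scatter is expected, with any real shift more likely toward stronger inhibition, since the measurements so far offer no room to detect weaker inhibition. The expected change is a number no higher from compound 2 to compound 4 (the limit leaves the size open). Compound 4 is estimated at 20000 nM, within an expected range of 3000 nM to 40000 nM.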

Compound 4, half-maximal inhibitory concentration: 5120 nM
Estimate against measurement, compound 4: 3.9-fold (0.59 log units) above; the measured number falls inside the stated range.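

Replacing furan-3-yl with iodo, on an aromatic carbon of a five-membered aromatic ring with 1 nitrogen, gives an at least 3.9-fold lower number from compound 2 to compound 4 (0.59 log units; beyond the scatter) in this assay. This shows that the group at this position can move the read-out, and that a single iodine atom in place of the five-membered aromatic ring is enough to bring a compound of this set onto the measurable scale, with compound 4 at 5120 nM. The true size of the step stays open because compound 2 carries only a limit: the limit of > 20000 nM in this assay, at which 3 of the 4 values shown sit.

Still open, on these data alone, is whether bromo, chloro or methyl at this place would give a number like that of compound 4. The compounds shown also cannot separate any contribution of iodo itself from the loss of furan-3-yl, which a plain hydrogen at this place would help to settle.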